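A few compounds are considered here, and "the series" means these few. Any claim that something is new, unique, unknown or untested is made for them only; others in the source may bear on it.

Measured compounds:
- compound 1, `CC(C)(C)c1cc(CCC(=O)NCCC2CCN(Cc3ccccc3)CC2)cc(C(C)(C)C)c1O`, 46900 nM
- compound 2, `CC(C)(C)c1cc(/C=C/C(=O)NCC2CCN(Cc3ccccc3)CC2)cc(C(C)(C)C)c1O`, 11700 nM
- compound 3, `Cc1ccccc1CN1CCC(CCNC(=O)/C=C/c2cc(C(C)(C)C)c(O)c(C(C)(C)C)c2)CC1`, 7200 nM

All three were tested in an assay on isolated protein for inhibition of Amine oxidase [flavin-containing] B (Homo sapiens), read by fluorescence, with stated times of 15 min and 20 min; on this read-out higher numbers stand for weaker inhibition and lower numbers for stronger inhibition. Compound 3 gives the lowest of the three numbers shown. Its nearest neighbour is compound 2, whose value sits within the usual scatter of compound 3, so the two cannot be told apart on these numbers. Compound 1 stands furthest away, and its gap to compound 3 lies beyond the scatter.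

Compound 4, `CC(C)(C)c1cc(/C=C/C(=O)NCCC2CCN(Cc3cccc(Cl)c3)CC2)cc(C(C)(C)C)c1O`, has not yet been measured in this assay. It differs from compound 3 in one place: 3-chlorophenyl in place of 2-methylphenyl on a saturated chain carbon bound to an amine nitrogen in a ring. The shared core, the linking chain and the amide are unchanged; only the group hanging from the saturated chain carbon bound to the amine nitrogen in a ring is exchanged, one aromatic ring for another of the same size.

Going by the values given here, no pair among the measured compounds shows what such an exchange does, so there is nothing here to point the step in either direction. The expectation for the step from compound 3 to compound 4 is therefore a 1.0-fold lower number from compound 3 to compound 4 (0.01 log units; within the scatter), that is, no change beyond the scatter. On that basis compound 4 is estimated at 7000 nM, with a range from 3000 nM to 16000 nM.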

Compound 4, half-maximal inhibitory concentration: 8700 nM
Beside the measured number, compound 4's estimate is 1.2-fold (0.09 log units) below it; the measured number falls inside the stated range.
By their numbers in this assay, from the lowest: compounds 3, 4 and 2 (each within the scatter of the next); then compound 1.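

In this assay, putting 3-chlorophenyl in place of 2-methylphenyl on a saturated chain carbon bound to an amine nitrogen in a ring gives a 1.2-fold higher number from compound 3 to compound 4 (0.08 log units; within the scatter) and so the two compounds cannot be told apart. Going by these compounds alone, this is the first direct reading of any exchange at this place, since no earlier pair differed in one place only, and it shows that this particular swap of one aromatic ring for another of the same size leaves the number inside the usual scatter. The exchange alters both the atom carried on the ring and where the name places it, so the matching numbers could reflect no effect from either alteration or two effects that cancel, and no measurement available here separates these readings.

A 2-chlorophenyl or a 3-methylphenyl group at this place would separate the atom from its location on the ring, and a plain phenyl group on the same chain and amide would show whether either added atom matters at all. Larger departures also remain open, such as a pyridine ring, a methoxy group or a carboxylic acid on the ring.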